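The source may report more compounds than this note shows. Statements on the series, on what has been measured and on what is new or still open speak of the compounds shown alone.

Measured compounds in a functional assay on KB cells (Homo sapiens) for cytotoxicity, read by MTT assay, with a stated time of 72 h; on this read-out higher numbers stand for weaker inhibition and lower numbers for stronger inhibition:
Compound 1, `C#CCn1cc(C(=O)NCCCOC(=O)CNC(=O)OC(C)(C)C)c(=O)c2cccnc21`: compound 1 gives 7000 nM.
Compound 2, `C#CCn1cc(C(=O)NCCCOC(=O)[C@H]2OC(C)(C)N(C(=O)OC(C)(C)C)[C@@H]2c2ccccc2)c(=O)c2ccc(Cl)nc21`: for compound 2 only the assay limit > 10000 nM is recorded.
Compound 3, `C#CCn1cc(C(=O)NCCCOC(=O)[C@H]2CCCN2C(=O)OC(C)(C)C)c(=O)c2ccc(Cl)nc21`: for compound 3 only the assay limit > 10000 nM is recorded.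

Compound 3 therefore stands at the edge of the numbers shown: the limit of > 10000 nM in this assay, at which 2 of the 3 values shown sit, so two of the three compounds return no number, and only compound 1 gives a measured value. Compound 4, `C#CCn1cc(C(=O)NCCCOC(=O)[C@H](C)NC(=O)OC(C)(C)C)c(=O)c2ccc(Cl)nc21`, differs from compound 3 by 1-((tert-butoxycarbonyl)amino)ethyl in place of 1-(tert-butoxycarbonyl)pyrrolidin-2-yl on a carbonyl carbon. Among the compounds with values here, no step between measured compounds is available, and compound 3 itself is a limit, so the step to compound 4 cannot be sized against the scatter; no change beyond the scatter is expected, and compound 4 may again report only the limit. Compound 4 is expected at 10000 nM, between 4000 nM and 30000 nM. The expected step is a number no higher from compound 3 to compound 4 (the limit leaves the size open).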

Compound 4, half-maximal inhibitory concentration: > 10000 nM
Compound 4 ended at the assay's limit (the forecaster's own chance of this, stated with the estimate: 55%); the middle value lies on the limit itself.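

Compound 3 and compound 4 both return only a limit, not a number, so no step can be read between them: the limit of > 10000 nM in this assay, at which 3 of the 4 values shown sit.

The compounds shown leave open how 1-((tert-butoxycarbonyl)amino)ethyl and 1-(tert-butoxycarbonyl)pyrrolidin-2-yl compare on this read-out.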